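Amide-tail variation on the oxadiazole amidoxime series

A few compounds are considered here, and "the series" means these few. Any claim that something is new, unique, unknown or untested is made for them only; others in the source may bear on it.

Compound 1 `O=C(NCCSc1nonc1/C(=N/O)Nc1ccc(F)c(C(F)F)c1)C1CS(=O)(=O)C1` is the reference point. In an assay for inhibition of Indoleamine 2,3-dioxygenase 1 (Homo sapiens), read by fluorescence, with a stated time of 1 h (on this read-out lower numbers stand for stronger inhibition and higher numbers for weaker inhibition), compound 1 gives 70 nM, the second highest of the three numbers recorded so far, though its gap to each of the other two lies within the scatter. Compound 2 `NS(=O)(=O)CC(=O)NCCSc1nonc1/C(=N/O)Nc1ccc(F)c(Br)c1` gives 71 nM in this assay, and compound 3 `CS(=N)(=O)CC(=O)NCCSc1nonc1/C(=N/O)Nc1ccc(F)c(Br)c1` gives 61 nM. Going by the values given here, the only single-point step recorded, a 1.2-fold lower number from compound 2 to compound 3 (0.07 log units; within the scatter), concerns the same amide tail region and is within the scatter.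

Compound 4 `CC(C)(O)CC(=O)NCCSc1nonc1/C(=N/O)Nc1ccc(F)c(C(F)F)c1` differs from compound 1 in that region: a group of 5 heavy atoms (4 carbon, 1 oxygen; no ring) in place of a group of 6 heavy atoms (3 carbon, 2 oxygen, 1 sulfur; one four-membered non-aromatic ring with 1 hetero atom), on a carbonyl carbon. Among the compounds with values here, the three measured compounds carry three different tails on the same amide and sit within the scatter of one another, and the one recorded step there is flat. Compound 1 and compound 4 therefore are expected to differ little in this assay; a 1.1-fold higher number from compound 1 to compound 4 (0.06 log units; within the scatter) is the step that this estimate implies, and no move beyond the scatter is expected in either direction. Compound 4 is estimated at 80 nM in this assay, with a range from 35 nM to 180 nM.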

Compound 4, half-maximal inhibitory concentration: 140 nM
Compound 4: the middle estimate sits 1.8-fold (0.24 log units) below what was measured; the measured number falls inside the stated range.
By their numbers in this assay, from the lowest: compounds 3, 1, 2 and 4 (each within the scatter of the next, the first and the last beyond it).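

In this assay, going by these compounds alone, the step on the carbonyl carbon, a 2.0-fold higher number from compound 1 to compound 4 (0.30 log units; within the scatter), stays within the scatter, although it is larger than the only earlier step at this site and lies at the edge of that scatter. Unlike the sulfur-bearing tails of compounds 1, 2 and 3, the 2-hydroxy-2-methylpropyl group of compound 4 has no sulfur and no ring, so the tail can change from a group with a four-membered non-aromatic ring to an open chain with no step beyond the scatter; it also moves from 0 hydrogen-bond donors and 2 hydrogen-bond acceptors to 1 of each. Nothing available gives a reason for the size of this step.

Open, as far as these compounds go, is whether the hydroxyl of the 2-hydroxy-2-methylpropyl group contributes at all, which a plain 2-methylpropyl chain on the same carbonyl carbon would test. Also open is how an amine, a carboxylic acid or a longer chain at this place would read, and so how far the flat picture extends beyond the neutral tails shown here.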